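The source may report more compounds than this note shows. Statements on the series, on what has been measured and on what is new or still open speak of the compounds shown alone.

Measured so far in a physicochemical assay for acid dissociation:
compound 1, `CCCCOc1noc2c1CNCC2`: 7.6
compound 2, `C#CCOc1noc2c1CNCC2`: 7.6
compound 3, `C=C(Br)COc1noc2c1CNCC2`: 7.6

Compound 3 stands level with compounds 1 and 2 at the digits shown; its nearest neighbour is compound 1 and its furthest is compound 2, and both gaps lie within the scatter. Compound 4, `C/C=C/COc1noc2c1CNCC2`, has not yet been measured in this assay. It differs from compound 3 as follows:
prop-1-en-1-yl in place of 1-bromoethenyl on a saturated chain carbon bound to an oxygen on an aromatic ring

Going by the values given here, three measured steps bear on this change, each a swap of the group on the saturated chain carbon bound to an oxygen on an aromatic ring: no change at the digits printed from compound 1 to compound 2 (within the scatter); no change at the digits printed from compound 1 to compound 3 (within the scatter); no change at the digits printed from compound 2 to compound 3 (within the scatter). None of the three moved the read-out beyond the scatter, whether the group present was propyl, ethynyl or 1-bromoethenyl. The step to prop-1-en-1-yl is expected to behave the same way, no change at the digits printed from compound 3 to compound 4 (within the scatter), with no change beyond the scatter. On that basis compound 4 is expected to give 7.6, within a range from 7.3 to 7.9.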

Compound 4, acid dissociation constant: 7.7
Beside the measured number, compound 4's estimate is 0.10 log units below it; low and high end bracket the measured number.
By their numbers in this assay, from the lowest: compounds 1, 2, 3 and 4 (each within the scatter of the next).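

In this assay, prop-1-en-1-yl on a saturated chain carbon bound to an oxygen on an aromatic ring stays within the scatter of all three earlier groups (a number 0.10 log units higher from compound 3 to compound 4 (within the scatter); a number 0.10 log units higher from compound 2 to compound 4 (within the scatter); a number 0.10 log units higher from compound 1 to compound 4 (within the scatter)). Compound 4 extends the flat picture to a fourth group at this place and shows that replacing 1-bromoethenyl, with its bromine, by an all-carbon group with a double bond produces no step beyond the scatter. No supporting evidence bears on this result.

Going by these compounds, whether an amine, a carboxylic acid or a longer chain at this place would also stay within the scatter remains open. The compounds shown vary only at this place, so the response of this assay to any change on the shared core also remains open.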